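A few compounds are considered here, and "the series" means these few. Any claim that something is new, unique, unknown or untested is made for them only; others in the source may bear on it.

Of the compounds shown here, three sharing one core have been measured in an assay (Rattus norvegicus) for inhibition of Fatty-acid amide hydrolase 1 (Homo sapiens); a higher number here means a weaker inhibitor, a lower number a stronger inhibitor. Compound 1 `Cc1ccnc(-c2cnc(C(=O)CCCCCCc3ccccc3)o2)c1` gives 0.6 nM, compound 2 `CC(=O)c1cnc(C(=O)CCCCCCc2ccccc2)o1` gives 2 nM, and compound 3 `O=C(CCCCCCc1ccccc1)c1ncc(C(=O)N2CCOCC2)o1` gives 24 nM. Compound 3 therefore stands highest of the three, with compound 2 nearest and compound 1 furthest from it; both of those gaps lie beyond the scatter. Going from compound 1 to compound 2 a 3.3-fold higher number from compound 1 to compound 2 (0.52 log units; beyond the scatter) and from compound 1 to compound 3 a 40-fold higher number from compound 1 to compound 3 (1.60 log units; beyond the scatter) shows that swapping the 4-methylpyridin-2-yl group for a carbonyl-linked group raised the number, while the step of a 12-fold higher number from compound 2 to compound 3 (1.08 log units; beyond the scatter) shows that the larger morpholin-4-yl on that carbonyl carbon raised it further.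

Compound 4 `O=C(CCCCCCc1ccccc1)c1ncc(-c2cc(=O)[nH]c(=O)[nH]2)o1` changes compound 3 at the same position: a group of 8 heavy atoms (4 carbon, 2 nitrogen, 2 oxygen; one six-membered aromatic ring with 2 hetero atoms) in place of a group of 8 heavy atoms (5 carbon, 1 nitrogen, 2 oxygen; one six-membered non-aromatic ring with 2 hetero atoms), on an aromatic carbon. The new group is a six-membered aromatic ring attached directly to the core, which in this series resembles compound 1 more than compound 2 or compound 3. The steps from compound 1 to compound 3 and from compound 2 to compound 3 were both large, so a move in the other direction is expected for compound 4, though smaller than those, because compound 1 gives 0.6 nM with a 4-methylpyridin-2-yl group that the entering ring only partly resembles. For compound 4 the estimated value in this assay is 8 nM, with a range from 2 nM to 40 nM, which would mean a step of a 3.0-fold lower number from compound 3 to compound 4 (0.48 log units; beyond the scatter) from compound 3 to compound 4.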

Compound 4, inhibition constant: 12 nM
Beside the measured number, compound 4's estimate is 1.5-fold (0.18 log units) below it; the range from low to high includes it.
By their numbers in this assay, from the lowest: compound 1; then compound 2; then compounds 4 and 3 (each within the scatter of the next).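

Swapping the (morpholin-4-yl)carbonyl for the new ring, a group with the same count of heavy atoms, gives a 2.0-fold lower number from compound 3 to compound 4 (0.30 log units; within the scatter) in this assay, so at this place on the core an aromatic ring bearing hydrogen-bond donors and a non-aromatic amide group cannot be told apart. Having a six-membered aromatic ring attached directly to the core is also not enough to match compound 1: both groups fit that description, yet the change gives a 20-fold higher number from compound 1 to compound 4 (1.30 log units; beyond the scatter), while the comparison with the much smaller acetyl group gives a 6.0-fold higher number from compound 2 to compound 4 (0.78 log units; beyond the scatter), so the identity of the ring matters here and group size alone does not order these compounds. No measurement at hand accounts for any of these differences.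

Going by these compounds, what remains open is which feature of the 4-methylpyridin-2-yl group sets compound 1 apart, a question that a plain phenyl ring or an unsubstituted pyridin-2-yl group at the same place could help to answer. It is also unclear how a carboxylic acid or a simple amine would fare on this aromatic carbon, and whether the order seen here would hold with a shorter chain on the ketone.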